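The compounds below may be only part of what the source reports. "The series", "measured", "known", "first", "only" and "open" are said of these compounds alone.

Measured in a functional assay on HeLa cells (Homo sapiens) for cytotoxicity (on this read-out higher numbers stand for weaker inhibition and lower numbers for stronger inhibition), so far:
compound 1, `C=C1C(=O)O[C@]2(C)CC[C@@H]1C[C@H](O)[C@@]1(C)CC[C@H](O1)C(=C)CC[C@H]2OC(C)=O`, a limit of > 20 ug/mL
compound 2, `C=C1C(=O)O[C@]2(C)CC[C@@H]1C[C@H](OC(C)=O)[C@@]1(C)CC[C@H](O1)C(=C)CC[C@H]2OC(C)=O`, a limit of > 20 ug/mL
compound 3, `C=C1C(=O)O[C@]2(C)CC[C@@H]1C[C@H](O)[C@@]1(C)CC[C@H](O1)[C@](C)(O)CCC2=O`, a limit of > 20 ug/mL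

Compound 2 differs from compound 1 by acetyl in place of hydrogen on an oxygen on a saturated carbon. The step that the two limits leave unreadable from compound 1 to compound 2, since both values sit at the limit of > 20 ug/mL in this assay, at which 3 of the 3 values shown sit. The difference between the cores of compound 1 and compound 3 is not broken down here. Compound 3 gives only a limit in this assay.

Compound 4, `C=C1C(=O)O[C@]2(C)CC[C@@H]1C[C@H](OC(C)=O)[C@@]1(C)CC[C@H](O1)[C@](C)(O)CCC2=O`, is not yet measured. It differs from compound 3 by acetyl in place of hydrogen on an oxygen on a saturated carbon, the same change at the same place as in the measured pair. Compound 4 is expected to give 40 ug/mL in this assay, a step that the limit leaves unreadable from compound 3 to compound 4, because the limit of > 20 ug/mL in this assay, at which 3 of the 3 values shown sit, is where every value shown sits, including that of the measured pair carrying this change, so another limit rather than a number is the likely outcome.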

Compound 4, half-maximal inhibitory concentration: > 20 ug/mL
Compound 4 was reported as a limit; the forecaster's own chance of this, stated with the estimate: 85%; the middle value is on the limit's open side.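

In this assay compound 4 gives > 20 ug/mL, a limit, and compound 3 also stands only as a limit, so no step can be read between compound 3 and compound 4. The compounds shown leave open how hydroxy to acetoxy shifts the read-out, because no value is a number: the limit of > 20 ug/mL in this assay, at which 4 of the 4 values shown sit.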